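The source may report more compounds than this note shows. Statements on the series, on what has been measured and on what is new or still open speak of the compounds shown alone.

Compound 1 `CC1(C)OC2O[C@@H](Cc3cn4cc(Cl)ccc4nc3=O)C(OCc3ccccc3)C2O1` gives > 1000000 nM in a functional assay on HeLa cells (Homo sapiens) for cytotoxicity, read by MTT assay, with a stated time of 24 h (a higher number here means a weaker inhibitor, a lower number a stronger inhibitor), a value that is a limit of the assay and not a number.
Compound 2 `O=c1nc2ccc(Br)cn2cc1Cc1ccccc1` gives 152000 nM in this assay.
Compound 3 `O=c1nc2ccccn2cc1Cc1ccc(Br)cc1` gives > 1000000 nM in this assay, again a limit of the assay and not a number.

Compound 3 therefore stands at the edge of what this assay can report, and it shares that place with compound 1, as the limit of > 1000000 nM in this assay, at which 2 of the 3 values shown sit, shows; only compound 2 gives a number among the three. No pair of these compounds differs in a single place, so no measured step is available for comparison.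

Compound 4 `O=c1nc2ccccn2cc1Cc1ccccc1` is not yet measured. It differs from compound 3 by hydrogen in place of bromo on an aromatic carbon. Taking away one bromine from a compound that already sits at a limit leaves little room for a measurable step in either direction, and compound 2, which also lacks a bromo on that ring, gives only a weak number. Compound 4 is therefore expected to remain near the limit, with the step from compound 3 estimated at a number no higher from compound 3 to compound 4 (the limit leaves the size open), which is expected to be no more than the scatter. The estimate for compound 4 is 1000000 nM, within the range 200000 nM to 5000000 nM, and a limit rather than a number is thought the more likely outcome.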

Compound 4, half-maximal inhibitory concentration: > 1000000 nM
Compound 4 was reported as a limit (the forecaster's own chance of this, stated with the estimate: 70%); the middle value lies on the limit itself.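

Compound 4 gives > 1000000 nM in this assay, a limit of the assay and not a number. For the compounds shown here, its comparison with compound 2 gives the first readable step, an at least 6.5-fold higher number from compound 2 to compound 4 (0.81 log units; beyond the scatter), so on the shared core, hydrogen in place of bromo takes a measured value to the limit. The step between compound 3 and compound 4 cannot be read, so a bromo on the six-membered aromatic ring of carbon only, para to a large group, shows no measurable effect in either direction, and most of the set now sits at one value: the limit of > 1000000 nM in this assay, at which 3 of the 4 values shown sit.

The compounds shown leave open whether the measured value of compound 2 is particular to bromine, or whether an amine or a nitrile at the same place on the shared core would also give a number. They also leave open whether a bromo or a carboxylic acid on the other ring would change the value of a compound that starts from a number rather than from a limit.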